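Trimming the Ethyl of Compound 1 Down to Methyl

The source may hold more compounds than are shown below. What is called first, only, known or untested is meant among the compounds shown, and "the series" means these compounds.

Compound 1 `C=CCn1ncc2c(CC)ncn2c1=O` is the starting point. In a functional assay for inhibition, with Homo sapiens as the target (on this read-out higher numbers stand for weaker inhibition and lower numbers for stronger inhibition), compound 1 reaches only a limit of the assay, > 48000 nM, rather than a number. Compound 2 `CSc1nncc2c(C)ncn12` likewise gives only a limit in this assay, > 48000 nM. Compound 3 `Cc1nc(C(C)C)n2c(S)nncc12` also stops at a limit in this assay, > 48000 nM. All three sit at the limit of > 48000 nM in this assay, at which 3 of the 3 values shown sit, so compound 1 stands level with its companions and no order among them can be read. Compound 4 `C=CCn1ncc2c(C)ncn2c1=O` differs from compound 1 by hydrogen in place of methyl on a saturated chain carbon bound to an aromatic carbon, which cut one bond further out reads ethyl to methyl. Among the measured compounds shown here, no measured pair shows what this change does, so no shift beyond the scatter of this assay is expected. The step that the limit leaves unreadable from compound 1 to compound 4 is expected to be negligible. Compound 4 is therefore expected to give about 60000 nM, somewhere between 30000 nM and 150000 nM, most probably again only a limit.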

Compound 4, half-maximal inhibitory concentration: > 48000 nM
Compound 4 was reported as a limit; the forecaster's own chance of this, stated with the estimate: 85%; the middle value lies beyond the limit too.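

Compound 1 and compound 4 both stop at a limit, so the step from ethyl to methyl cannot be read: the limit of > 48000 nM in this assay, at which 4 of the 4 values shown sit.

The compounds shown leave open how strongly any of them truly acts in this assay, since none yet gives an actual number.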